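The source may hold more compounds than are shown below. What is called first, only, known or untested is meant among the compounds shown, and "the series" means these compounds.

Measured in a functional assay on the whole organism (strain Swiss albino) for inhibition, with Mus musculus as the target, in the writhing test, with stated times of 30 min and 15 min, at a dose of 50 mg/kg by the oral route; a lower number here means less inhibition, a higher number more inhibition at the dose given (going by the name of the read-out):
compound 1 `Cc1ccc(/N=C2/NC(=O)/C(=C/c3ccccn3)S2)cc1` gives 43.2%
compound 2 `O=C1N/C(=N\Nc2ccc([N+](=O)[O-])cc2[N+](=O)[O-])S/C1=C\c1ccccn1` gives 68.7%
compound 3 `COc1ccc(/N=C2\NC(=O)/C(=C/c3ccccn3)S2)cc1` gives 42.4%

Compound 1 stands second highest of the three numbers. Compound 3 lies within the scatter of compound 1, so no order can be read between these two. Compound 2 lies higher than compound 1, beyond the scatter.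

Compound 4 `O=C1N/C(=N/c2ccccc2Cl)S/C1=C\c1ccccn1` is not yet measured. It differs from compound 1 in one place: 2-chlorophenyl in place of 4-methylphenyl on a double-bonded nitrogen. Going by the values given here, no measured pair shows this change, so there is no step to rest on. Compound 1 and compound 3 fall within the scatter of each other, so a step of small size, not beyond the scatter, is expected here, if anything slightly upward. Compound 4 is estimated at 47%, between 33% and 61%. The expected step in this assay is then a number 3.8 percentage points higher from compound 1 to compound 4 (within the scatter).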

Compound 4, a percentage reported as inhibition, in the whole organism at one dose (the size of the read-out at that dose, not a potency): 36.2%
Compound 4: middle estimate off by 10.8 percentage points, on the high side, and the stated range covers the measured number.
By their numbers in this assay, from the lowest: compounds 4, 3 and 1 (each within the scatter of the next); then compound 2.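

In this assay the change to 2-chlorophenyl in place of 4-methylphenyl on a double-bonded nitrogen gives a number 7 percentage points lower from compound 1 to compound 4 (within the scatter) and so stays within the scatter. Going by these compounds alone, this is the first one-place comparison, and at this dose it does not separate these two aryl groups at this position. No available measurement accounts for the result.

As far as these compounds go, whether 4-chlorophenyl or unsubstituted phenyl would behave the same here remains open. From the compounds shown here alone, it is also open whether a dimethylamino group or a carboxylic acid on this ring would produce a step beyond the scatter.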